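Working notes: bromo in place of cyclohexyl

The source may hold more compounds than are shown below. What is called first, only, known or untested is meant among the compounds shown, and "the series" means these compounds.

Measured so far:
compound 1 `CCCCCCCc1c(C)nc2ccccc2c1O` gives 5100 nM
compound 2 `Cc1[nH]c2ccccc2c(=O)c1C1CCCCC1` gives > 41400 nM (a limit)
compound 3 `Cc1[nH]c2ccccc2c(=O)c1Cc1ccccc1` gives > 40100 nM (a limit)

In an ADME assay on J774 cells (Mus musculus) for cytotoxicity (a lower number here means that less compound is needed, a higher number that more compound is needed for the effect), compound 2 stands at a limit and not at a number (> 41400 nM). Compound 3 also reports only a limit (> 40100 nM). Compound 1 alone gives a number (5100 nM).

Compound 4 `Cc1[nH]c2ccccc2c(=O)c1Br` is still unmeasured. It carries bromo in place of cyclohexyl on an aromatic carbon and stays ortho to a methyl group. Going by the values given here, no measured pair differs in one place only, so the size of this change has no direct precedent. Compound 3 carries another group on that carbon and also stops at a limit (> 40100 nM). Going by that limit for compound 3, no step beyond the scatter is expected in this assay, and another limit is the likely report. The expected size of the step of an at least 1.0-fold lower number from compound 2 to compound 4 (0.01 log units; that floor lies within the scatter) is therefore small. The estimate for compound 4 is 40000 nM with an expected range of 15000 nM to 60000 nM on repeated measurement.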

Compound 4, half-maximal effective concentration: > 42000 nM
Compound 4 ended at the assay's limit; the forecaster's own chance of this, stated with the estimate: 70%; middle value at least 1.0-fold (0.02 log units) away from the limit.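

Compound 2 and compound 4 both end at limits in this assay, so no step can be read between them. The compounds shown leave open how far, if at all, bromo in place of cyclohexyl on an aromatic carbon shifts the number in this assay.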